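The source may hold more compounds than are shown below. What is called first, only, known or untested is meant among the compounds shown, and "the series" means these compounds.

Working notes on the series sharing the core of compound 1 (`CCn1c(C(=O)NCCN(C)C)ccc1C(CC)(CC)c1ccc(OCC(O)C(C)(C)C)c(C)c1`), read in a functional assay on Caco-2 cells (Homo sapiens), read by MTT assay, with a stated time of 48 h; on this read-out higher numbers stand for weaker inhibition and lower numbers for stronger inhibition. Compound 1 gives 1300 nM, compound 2 (`C#CCNC(=O)c1ccc(C(CC)(CC)c2ccc(OCC(O)C(C)(C)C)c(C)c2)n1CC`) gives 39100 nM and compound 3 (`CC[C@@H](C)[C@H](NC(=O)c1ccc(C(CC)(CC)c2ccc(OCC(O)C(C)(C)C)c(C)c2)n1CC)C(=O)O`) gives 3400 nM. Compound 3 therefore holds the second highest of the three numbers, nearer to compound 1 than to compound 2.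

The next entry is compound 4 (`CCn1c(C(=O)OCc2ccc(F)cc2)ccc1C(CC)(CC)c1ccc(OCC(O)C(C)(C)C)c(C)c1`): (4-fluorobenzyl)oxy in place of (1-carboxy-2-methylbutyl)amino on a carbonyl carbon. In words, this is (4-fluorobenzyl)oxy in place of (1-carboxy-2-methylbutyl)amino on a carbonyl carbon.

The three measured steps all vary the group on the amide-type nitrogen: a 30-fold higher number from compound 1 to compound 2 (1.48 log units; beyond the scatter) is large, a 2.6-fold higher number from compound 1 to compound 3 (0.42 log units; beyond the scatter) is modest and a 12-fold lower number from compound 2 to compound 3 (1.06 log units; beyond the scatter) is large. Changes at this place can thus shift the number substantially in either direction. Going by the values given here, no measured compound carries an oxygen-linked group on this carbonyl, so no direct precedent exists. Compound 2 also lacks both the dimethylamino and the carboxy group, and it stands at 39100 nM, which tilts the expectation upward.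

A modest rise is expected in this assay, with the estimated change being a 2.6-fold higher number from compound 3 to compound 4 (0.42 log units; beyond the scatter). For compound 4 the expected value is 9000 nM, with an estimated range from 2000 nM to 35000 nM.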

Compound 4, half-maximal inhibitory concentration: > 50000 nM
Compound 4 gave a limit, no number; the forecaster's own chance of this, stated with the estimate: 10%; middle value at least 5.5-fold (0.74 log units) away from the limit.
By their numbers in this assay, from the lowest: compound 1; then compound 3; then compound 2. At a limit, above all of these: compound 4.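

In this assay compound 4 gives a limit of the assay and not a number: the limit of > 50000 nM in this assay, at which 1 of the 4 values shown sits. Going by these compounds alone, with an oxygen-linked group on this carbonyl carbon the series reaches that limit for the first time, and the change gives an at least 14-fold higher number from compound 3 to compound 4 (1.16 log units; beyond the scatter) and an at least 38-fold higher number from compound 1 to compound 4 (1.58 log units; beyond the scatter), so this place tolerates the loss of the amide-type nitrogen far less well than compound 1 and compound 3 alone could show. Against the propargylamino compound the reading is much weaker: an at least 1.2-fold higher number from compound 2 to compound 4 (0.10 log units; that floor lies within the scatter) leaves compound 4 without a firm order relative to compound 2, so a large step away from compound 1 and compound 3 does not set compound 4 clearly apart from every amide-type compound.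

The change swaps the linking atom and brings in the 4-fluorobenzyl ring in a single step, so the compounds shown do not tell which of the two carries the loss. A (4-fluorobenzyl)amino group on the same carbonyl carbon would separate them, and an ester bearing a 2-(dimethylamino)ethyl group would test the oxygen link with a side chain already seen in compound 1.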